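Serine amides: from oxamide to methacrylamide

A few compounds are considered here, and "the series" means these few. Any claim that something is new, unique, unknown or untested is made for them only; others in the source may bear on it.

Measured compounds:
compound 1 `CC(C)C(=O)N[C@@H](CO)C(=O)O` — 49%
compound 2 `NC(=O)C(=O)N[C@@H](CO)C(=O)O` — "not determined" (no result reported)

Two serine amides have been examined in an ADME assay on microsomes from liver (Mus musculus) for metabolic stability, with a stated time of 30 min; a higher number here means that more of the compound is left, a lower number that less of the compound is left. Compound 1 `CC(C)C(=O)N[C@@H](CO)C(=O)O` is the isobutyramide, and in this assay compound 1 gives 49%. Compound 2 `NC(=O)C(=O)N[C@@H](CO)C(=O)O` carries a carbamoyl group on the amide carbonyl carbon; in this assay compound 2 gives "not determined" (no result reported), so no number is available for it, and it cannot be ranked against compound 1.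

Compound 3 `C=C(C)C(=O)N[C@@H](CO)C(=O)O` has not yet been measured. It differs from compound 2 in one place: 1-methylethenyl in place of carbamoyl on a carbonyl carbon. Within the data shown here, since compound 2 has no number in this assay, no step can be computed for this change, and no direction can be stated from the data alone. What remains as a point of reference is compound 1, which gives 49% in this assay.

In this assay compound 3 is expected to give about 45%, with a range from 20% to 70%, an estimate placed near compound 1 because compound 1 gives 49% and because no value for compound 2 is there to anchor a step.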

Compound 3, percent of the compound remaining: 68%
Compound 3: the middle estimate sits 23 percentage points below what was measured; the measured number falls inside the stated range.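

Placing 1-methylethenyl in place of isopropyl on a carbonyl carbon gives a number 19 percentage points higher from compound 1 to compound 3 (beyond the scatter) in this assay, the first step that can be read in this series. It shows that the read-out is not indifferent to the group at this place on the shared core, since two groups of similar size by name, differing in one double bond outside aromatic rings, are separated by more than the usual scatter. Nothing at hand accounts for the difference, so the step stands as an observation without an explanation.

The steps involving compound 2 cannot be read, so the carbamoyl group remains unplaced relative to both isopropyl and 1-methylethenyl. From the compounds shown here alone, it also remains open whether a longer chain, a cyclopropyl group or a tert-butyl group on the same carbonyl carbon would fall nearer to compound 1 or to compound 3, and whether this single step would hold on any core other than this serine amide.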